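The source may report more compounds than this note shows. Statements on the series, on what has been measured and on what is new or still open speak of the compounds shown alone.

Measured in a functional assay on RAW264.7 cells (Mus musculus) for inhibition, with a stated time of 30 min; a higher number here means a weaker inhibitor, a lower number a stronger inhibitor:
Compound 1 `C=C1C(=O)OC[C@@H]1CCOC(=O)Nc1ccc(C(C)C)cc1`: 1580 nM
Compound 2 `C=C1C(=O)OC[C@@H]1CCOC(=O)Nc1ccc(I)cc1`: 790 nM
Compound 3 `C=C1C(=O)OC[C@@H]1CCOC(=O)Nc1ccc(Cl)cc1`: 1070 nM

Compound 3 holds the second-highest number of the three, but its gaps to compound 2 and to compound 1 both stay within the scatter, so no order among the three can be read from this assay. Compound 4 `C=C1C(=O)OC[C@@H]1CCOC(=O)Nc1ccc(OC)cc1` is not yet measured; it carries methoxy in place of chloro on an aromatic carbon.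

Two measured steps change the same aromatic carbon: a 1.5-fold lower number from compound 1 to compound 3 (0.17 log units; within the scatter) and a 1.4-fold higher number from compound 2 to compound 3 (0.13 log units; within the scatter), each within the scatter. Going by the values given here, no methoxy analogue has been measured, so the change is unprecedented here. Given that the substituents tried so far hardly moved this assay, the step from compound 3 to compound 4 is expected to be small, a 1.1-fold higher number from compound 3 to compound 4 (0.05 log units; within the scatter). Compound 4 is therefore estimated at 1200 nM, with a range of 500 nM to 3000 nM.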

Compound 4, half-maximal inhibitory concentration: 1090 nM
Beside the measured number, compound 4's estimate is 1.1-fold (0.04 log units) above it, within the range that was stated.
By their numbers in this assay, from the lowest: compounds 2, 3, 4 and 1 (each within the scatter of the next).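

In this assay, replacing chloro with methoxy adds a hydrogen-bond acceptor on the aromatic carbon, yet the step stays within the scatter (a 1.0-fold higher number from compound 3 to compound 4 (0.01 log units; within the scatter)). The steps from the two other groups are also within the scatter (a 1.4-fold higher number from compound 2 to compound 4 (0.14 log units; within the scatter); a 1.4-fold lower number from compound 1 to compound 4 (0.16 log units; within the scatter)), so methoxy cannot be separated from iodo, chloro or isopropyl at this position. No measurement at hand accounts for this flat result. Still open, from the compounds shown here alone, is whether an amine, a carboxylic acid or a longer alkoxy chain on this aromatic carbon would separate from these four groups.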